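The source may hold more compounds than are shown below. What is called first, only, known or untested is meant among the compounds shown, and "the series" means these compounds.

Compounds measured so far:

Compound 1 `COc1ccc(-c2cc(/C=C/C(=O)c3ccc(N)cc3)[nH]n2)cc1` – 88%
Compound 2 `COc1cc(-c2cc(/C=C/C(=O)c3ccc(N)cc3)[nH]n2)cc(OC)c1OC` – 81%

Both compounds were tested in a functional assay on 786-0 cells (Homo sapiens) for cytotoxicity, read by sulforhodamine B assay, with a stated time of 48 h, tested at 1 uM (on this read-out higher numbers stand for a weaker effect at the one concentration tested and lower numbers for a stronger effect), and each carries the same core with methoxy groups on one ring. In this assay compound 2 gives 81%, the smaller of the two numbers, yet the gap to compound 1 is within the usual scatter, so the two cannot be told apart on these data.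

Compound 3 `COc1ccc(-c2cc(/C=C/C(=O)c3ccc(N)cc3)[nH]n2)cc1OC` has not been measured. It differs from compound 2 in one place: hydrogen in place of methoxy on an aromatic carbon Compound 3 therefore carries two methoxy groups, compound 1 one and compound 2 three.

For the measured compounds named here, no measured step between compounds is available to say how such a change plays out here. Because compound 1 gives 88% and compound 2 gives 81%, a step of a number 4 percentage points higher from compound 2 to compound 3 (within the scatter) is expected, none beyond the scatter. Compound 3 is estimated at 85%, within the range 70% to 98%.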

Compound 3, a percentage reported as activity, at one concentration (the size of the read-out at that concentration, not a potency): 87%
Beside the measured number, compound 3's estimate is 2 percentage points below it; the range from low to high includes it.
By their numbers in this assay, from the lowest: compounds 2, 3 and 1 (each within the scatter of the next).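

In this assay, hydrogen in place of methoxy on the aromatic carbon ortho to a methoxy group gives a number 6 percentage points higher from compound 2 to compound 3 (within the scatter), and methoxy in place of hydrogen on an aromatic carbon gives a number 1 percentage points lower from compound 1 to compound 3 (within the scatter). Each of these single swaps now has a measured step, and neither separates the two compounds it links, so between methoxy and hydrogen at these places the read-out at the one concentration tested shows no difference that can be told from scatter. No other measurement here bears on the reason for this result.

Going by these compounds, whether a different group on the same aromatic carbon, such as an amine, a carboxylic acid or a longer alkoxy chain, would give a step beyond the scatter remains open. On these data alone, whether these compounds would differ at other concentrations also remains open.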